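Naphthylmethyl sulfanyl series: ketone-derived hydrazone analogue expected

The source may report more compounds than this note shows. Statements on the series, on what has been measured and on what is new or still open speak of the compounds shown alone.

Measured compounds:
compound 1 `Cc1cc(S(=O)(=O)/N=C(\N)N/N=C/C#Cc2ccccc2)c(SCc2ccc(C(F)(F)F)cc2)cc1Cl`: 70000 nM
compound 2 `C/C(C#Cc1ccccc1)=N\N/C(N)=N/S(=O)(=O)c1cc(C)c(Cl)cc1SCc1ccc(C(F)(F)F)cc1`: 160000 nM
compound 3 `Cc1cc(S(=O)(=O)/N=C(\N)N/N=C/C#Cc2ccccc2)c(SCc2cccc3ccccc23)cc1Cl`: 10000 nM

All three were tested in a functional assay on HCT-116 cells (Homo sapiens) for antiproliferative activity, read by MTT assay, with a stated time of 72 h; on this read-out higher numbers stand for weaker inhibition and lower numbers for stronger inhibition. Compound 1 and compound 2 share a core and differ by a group of 11 heavy atoms (10 carbon, 1 nitrogen; one six-membered aromatic ring of carbon only) in place of a group of 10 heavy atoms (9 carbon, 1 nitrogen; one six-membered aromatic ring of carbon only), on an amine nitrogen; that change gave a 2.3-fold higher number from compound 1 to compound 2 (0.36 log units; beyond the scatter). Compound 3 differs from compound 1 by naphthalen-1-yl in place of 4-(trifluoromethyl)phenyl on a saturated chain carbon bound to a sulfur, and gave a 7.0-fold lower number from compound 1 to compound 3 (0.85 log units; beyond the scatter), the lowest number of the three.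

Compound 4 `C/C(C#Cc1ccccc1)=N\N/C(N)=N/S(=O)(=O)c1cc(C)c(Cl)cc1SCc1cccc2ccccc12` is not yet measured. It differs from compound 3 by a group of 11 heavy atoms (10 carbon, 1 nitrogen; one six-membered aromatic ring of carbon only) in place of a group of 10 heavy atoms (9 carbon, 1 nitrogen; one six-membered aromatic ring of carbon only), on an amine nitrogen, the same change as that from compound 1 to compound 2, made at a place described in the same words, so it is the same kind of change on the core of compound 3. The two cores differ by naphthalen-1-yl in place of 4-(trifluoromethyl)phenyl on a saturated chain carbon bound to a sulfur as told above.

In this assay the expected step for compound 4 is a 2.3-fold higher number from compound 3 to compound 4 (0.36 log units; beyond the scatter). Within the data shown here, that expectation rests on the single earlier instance of this change, a 2.3-fold higher number from compound 1 to compound 2 (0.36 log units; beyond the scatter). The estimate for compound 4 is 23000 nM, with a range from 8000 nM to 65000 nM.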

Compound 4, half-maximal inhibitory concentration: 105000 nM
The estimate for compound 4 lay 4.6-fold (0.66 log units) below the measured number, outside the stated range (above it).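

The change on the amine nitrogen gave an 11-fold higher number from compound 3 to compound 4 (1.02 log units; beyond the scatter) in this assay, the same direction as on the core of compound 1 but not the same size: the same change on two cores in this assay, a 2.3-fold higher number (0.36 log units; beyond the scatter) from compound 1 to compound 2 and an 11-fold higher number (1.02 log units; beyond the scatter) from compound 3 to compound 4, 4.6-fold (0.66 log units) apart, beyond the scatter of two such steps

Naphthalen-1-yl in place of 4-(trifluoromethyl)phenyl gave a 1.5-fold lower number from compound 2 to compound 4 (0.18 log units; within the scatter), so the step seen on the core of compound 1 did not carry over to the core of compound 2: the same change on two cores in this assay, a 7.0-fold lower number (0.85 log units; beyond the scatter) from compound 1 to compound 3 and a 1.5-fold lower number (0.18 log units; within the scatter) from compound 2 to compound 4, 4.6-fold (0.66 log units) apart, beyond the scatter of two such steps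

The two changes therefore do not add up across these four compounds, but one such set shows neither how general this is nor what lies behind it.

Open, as far as these compounds go, is whether the size of the step on the amine nitrogen also depends on the group on the saturated chain carbon bound to a sulfur when that group is phenyl or naphthalen-2-yl. Also open, from the compounds shown here alone, is whether an ethyl group in place of the added methyl follows compound 2 and compound 4.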